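Swapping acetyl for dimethylamino on the aryl ring

The compounds below may be only part of what the source reports. "The series", "measured", "known", "first", "only" and "open" are said of these compounds alone.

The study measured cytotoxicity in a functional assay on NCI/ADR-RES cells (Homo sapiens) for cytotoxicity, read by sulforhodamine B assay, with a stated time of 48 h, tested at 100 nM; on this read-out lower numbers stand for a stronger effect and higher numbers for a weaker effect at the one concentration tested. Of the compounds shown here, two have numbers so far. Compound 1, `COc1cc(C)cc(-c2c(-c3ccnc(-c4ccc(C(C)=O)cc4)c3)cnn2CC#N)c1`, gives 83% in this assay, the higher of the two values. Compound 2, `COc1cc(C)cc(-c2nn(CC#N)cc2-c2ccnc(-c3ccc(N(C)C)cc3)c2)c1`, gives -22% in this assay, a value far below that of compound 1 and well beyond the usual scatter of the measurement.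

The next compound, compound 3, `COc1cc(C)cc(-c2c(-c3ccnc(-c4ccc(N(C)C)cc4)c3)cnn2CC#N)c1`, has not yet been measured. It differs from compound 1 in one place: dimethylamino in place of acetyl on an aromatic carbon. The rest of the shared core is unchanged.

Within the data shown here, no step between measured compounds that differ in a single place is available, so the size of the change cannot be read directly. Among the measured compounds shown here, still, the only other measured compound, compound 2, shows a number very different from compound 1 in this assay, which suggests that large swings are possible. Compound 3 is therefore expected to sit far below compound 1, with an estimated step of a number 83 percentage points lower from compound 1 to compound 3 (beyond the scatter). The value of compound 3 in this assay is estimated at 0%, within a range from -40% to 60%.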

Compound 3, a percentage reported as activity, at one concentration (the size of the read-out at that concentration, not a potency): 2%
For compound 3 the middle estimate is 2 percentage points below the measured one, within the range that was stated.
By their numbers in this assay, from the lowest: compound 2; then compound 3; then compound 1.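

In this assay, among these compounds, the one exchange on an aromatic carbon para to a large group comes with a number 81 percentage points lower from compound 1 to compound 3 (beyond the scatter) and is the first step that can be read across a single change. It shows that this place on the shared core is not indifferent to what it carries: going from 4-acetylphenyl to 4-(dimethylamino)phenyl moves the read-out by a large amount at the one concentration tested. The leaving and entering groups match in heavy atoms, hydrogen-bond donors and hydrogen-bond acceptors, so these counts do not tell the two groups apart, and no measurement on hand explains the step.

The compounds shown leave open whether a primary amine or a methylamino group at this place would read like dimethylamino, and whether a carboxylic acid or a methyl ester would read like acetyl. They also leave open whether a longer chain on the nitrogen, such as diethylamino, or a ring amine such as morpholine would keep the low number seen with dimethylamino.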